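This account rests on a few compounds, and the source may have more. Where it says the series, first, only, none or still open, it means among the compounds named here.

The measured compounds:

compound 1, `[O-][S+](Cc1[nH]c2ccccc2c1Sc1ccccc1)c1ccccc1`, with 400 nM;
compound 2, `[O-][S+](Cc1[nH]c2ccc(Cl)cc2c1Sc1ccccc1)c1ccccc1`, with 800 nM;
compound 3, `CNC(=O)c1[nH]c2ccccc2c1Sc1ccccc1`, with 800 nM.

All three were tested in a functional assay on MT4 cells (Homo sapiens) for inhibition; a lower number here means a stronger inhibitor, a higher number a weaker inhibitor. Compound 1 and compound 2 share a core and differ in one place: chloro in place of hydrogen on an aromatic carbon. That change gave a 2.0-fold higher number from compound 1 to compound 2 (0.30 log units; within the scatter). Compound 3 carries a different core, and the difference between the two cores is not broken down here. In this assay compound 3 gives 800 nM, level with compound 2 at the digits shown, and its gap to compound 1 stays within the scatter, so no order can be read among the three.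

Compound 4, `CNC(=O)c1[nH]c2ccc(Cl)cc2c1Sc1ccccc1`, has not yet been measured. It differs from compound 3 in one place: chloro in place of hydrogen on an aromatic carbon. Among the compounds with values here, this is the same change as the one made between compound 1 and compound 2, entering at the same place on the ring. Within the data shown here, only one measured instance of it exists, so the expectation rests on a single step. Because a 2.0-fold higher number from compound 1 to compound 2 (0.30 log units; within the scatter) stayed within the scatter, the step expected from the same change here is a 2.0-fold higher number from compound 3 to compound 4 (0.30 log units; within the scatter), a shift that itself would fall inside the usual scatter. Compound 4 is therefore estimated at 1600 nM in this assay. The likely range for compound 4 is taken as 600 nM to 4000 nM, wide enough to cover the possibility that the change does nothing on this second core.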

Compound 4, concentration for 95% inhibition: 200 nM
Beside the measured number, compound 4's estimate is 8.0-fold (0.90 log units) above it; the measured number lies below the stated range.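

In this assay, chloro in place of hydrogen on an aromatic carbon gave a 4.0-fold lower number from compound 3 to compound 4 (0.60 log units; beyond the scatter), and this step does not match the one seen with the same change on the core of compound 1: the same change on two cores in this assay, a 2.0-fold higher number (0.30 log units; within the scatter) from compound 1 to compound 2 and a 4.0-fold lower number (0.60 log units; beyond the scatter) from compound 3 to compound 4, 8.0-fold (0.90 log units) apart, beyond the scatter of two such steps In this series, then, a step read on one core did not hold on the other, and the outcome of this change depended on the core that carried it, at least for these two cores. This does not show why the two steps part, and it gives no general rule, as each core is represented by a single pair of compounds, the earlier step lies within the scatter and the new one is modest.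

The compounds shown leave open whether fluoro, bromo or methyl in the same place would follow chloro on the core of compound 3, or would instead behave as chloro did on the core of compound 1. They also leave open whether the step seen with chloro would survive if a longer chain took the place of the methyl group on the amide of compound 3.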